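A Second Chloro Group and Cell Growth Inhibition

The source may report more compounds than this note shows. Statements on the series, on what has been measured and on what is new or still open speak of the compounds shown alone.

Three measured compounds share one core. In a functional assay on NCI-H292 cells (Homo sapiens) for cytotoxicity, read by MTT assay, with a stated time of 72 h, tested at 10 ug/mL (on this read-out lower numbers stand for less inhibition of growth and higher numbers for more inhibition of growth at the one concentration tested), compound 1 `O=C1NC(=S)/C(=C/c2cccc(Cl)c2)S1` gives 30.9%. Compound 3 `O=C1NC(=S)/C(=C/c2ccc(Cl)c(Cl)c2)S1` differs from compound 1 by chloro in place of hydrogen on an aromatic carbon, and in this assay compound 3 gives 43.3%, a step of a number 12.4 percentage points higher from compound 1 to compound 3 (beyond the scatter). Compound 2 `O=C1NC(=S)/C(=C/c2ccccc2Cl)S1` has the same atoms as compound 1 joined differently; the difference between the two cores is not broken down here. In this assay compound 2 gives 45%, which lies within the scatter of compound 3 and beyond it relative to compound 1.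

Compound 4 `O=C1NC(=S)/C(=C/c2ccc(Cl)cc2Cl)S1` is not yet measured. It differs from compound 2 by chloro in place of hydrogen on an aromatic carbon, the same kind of change as from compound 1 to compound 3, though here the entering chloro sits meta to a chloro group rather than ortho to it. Because the earlier step was a number 12.4 percentage points higher from compound 1 to compound 3 (beyond the scatter), for compound 4 a smaller step of a number 6 percentage points higher from compound 2 to compound 4 (within the scatter) is expected. Compound 4 is estimated at 51%, likely between 38% and 64%.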

Compound 4, percent growth inhibition at one concentration: 38.4%
For compound 4 the middle estimate is 12.6 percentage points above the measured one; measured number inside the range.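

On the core of compound 2, chloro in place of hydrogen on an aromatic carbon gives, in this assay, a number 6.6 percentage points lower from compound 2 to compound 4 (within the scatter). The same change thus does not carry over from one core to the other with the same size: the same change on two cores in this assay, a number 12.4 percentage points higher (beyond the scatter) from compound 1 to compound 3 and a number 6.6 percentage points lower (within the scatter) from compound 2 to compound 4, 19 percentage points apart, beyond the scatter of two such steps
With only these two pairs, this shows that the step cannot simply be transferred within the series, but it does not show why, nor whether the entering chloro group's place, meta to a chloro group in compound 4, accounts for the gap.

The compounds shown leave open how a methoxy group, an amine or a carboxylic acid would behave at these ring positions. They also leave open whether these steps would hold at other concentrations.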